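Phenyl-to-methyl swap on the tetrazole, second instance

A few compounds are considered here, and "the series" means these few. Any claim that something is new, unique, unknown or untested is made for them only; others in the source may bear on it.

Measured compounds:
compound 1 `Cc1ccc(-c2cs/c(=N/NC(=O)CSc3nnnn3-c3ccccc3)n2-c2ccccc2)cc1` with 29.5%
compound 2 `Cc1ccc(-c2cs/c(=N/NC(=O)CSc3nnnn3C)n2-c2ccccc2)cc1` with 44.3%
compound 3 `O=C(CSc1nnnn1-c1ccccc1)N/N=c1/scc(-c2ccccc2)n1-c1ccccc1` with 36.7%

All three were run in a functional assay on C6 cells (Rattus norvegicus) for cytotoxicity, read by MTT assay, with a stated time of 24 h, tested at 50 ug/mL; a higher number here means a weaker effect of the compound at the concentration tested, a lower number a stronger effect. Compound 1 gives 29.5%, compound 2 gives 44.3%, compound 3 gives 36.7%.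

Compound 2 differs from compound 1 by methyl in place of phenyl on an aromatic nitrogen. That change made the step of a number 14.8 percentage points higher from compound 1 to compound 2 (beyond the scatter). Compound 3 differs from compound 1 by hydrogen in place of methyl on an aromatic carbon, with the step of a number 7.2 percentage points higher from compound 1 to compound 3 (within the scatter), so compound 1 and compound 3 cannot be told apart on these numbers.

Compound 4 `Cn1nnnc1SCC(=O)N/N=c1/scc(-c2ccccc2)n1-c1ccccc1` is not yet measured. It differs from compound 3 by methyl in place of phenyl on an aromatic nitrogen, the same change as that between compound 1 and compound 2 in the same place. Within the data shown here, the only precedent is the single step of a number 14.8 percentage points higher from compound 1 to compound 2 (beyond the scatter). The step from compound 3 to compound 4 is therefore expected to be a number 12.3 percentage points higher from compound 3 to compound 4 (beyond the scatter), resting on that one pair.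

For compound 4 in this assay the expected value is 49%, between 37% and 61%.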

Compound 4, a percentage reported as activity, at one concentration (the size of the read-out at that concentration, not a potency): 56.2%
Estimate against measurement, compound 4: 7.2 percentage points below, within the range that was stated.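

In this assay, 1-methyl-1H-tetrazol-5-yl in place of 1-phenyl-1H-tetrazol-5-yl gives a number 19.5 percentage points higher from compound 3 to compound 4 (beyond the scatter), and the change carries from one core to the other with the same sign and a size that cannot be told apart: the same change on two cores in this assay, a number 14.8 percentage points higher (beyond the scatter) from compound 1 to compound 2 and a number 19.5 percentage points higher (beyond the scatter) from compound 3 to compound 4, 4.7 percentage points apart, within the scatter of two such steps. Among these compounds, the other change, hydrogen in place of methyl on an aromatic carbon, gives a number 11.9 percentage points higher from compound 2 to compound 4 (beyond the scatter), and its size also does not differ between the two pairs, although only this step lies beyond the scatter: the same change on two cores in this assay, a number 7.2 percentage points higher (within the scatter) from compound 1 to compound 3 and a number 11.9 percentage points higher (beyond the scatter) from compound 2 to compound 4, 4.7 percentage points apart, within the scatter of two such steps. This shows that the two changes transfer across these four compounds, but it rests on two pairs of closely related structures, gives no cause for either step, and says nothing of potency, since each number is a read-out at one concentration.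

Still open, as far as these compounds go, is whether the step on the nitrogen holds for ethyl, a longer chain, or a chain ending in an amine or a carboxylic acid. Also open, from the compounds shown here alone, is how methoxy or chlorine would behave in place of the methyl on the aromatic carbon.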